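Pyrrolidin-1-yl for diethylamino on a thiocarbonyl carbon

A few compounds are considered here, and "the series" means these few. Any claim that something is new, unique, unknown or untested is made for them only; others in the source may bear on it.

Three compounds of the series have been run in a functional assay on SW480 cells (Homo sapiens) for antiproliferative activity, read by MTT assay, with a stated time of 72 h; a higher number here means a weaker inhibitor, a lower number a stronger inhibitor. Compound 1 `COc1ccc2occ(CSC(=S)N3CCCCC3)c(=O)c2c1` gives 6700 nM in this assay. Compound 2 `CCN(CC)C(=S)SCc1cc(=O)c2ccc(Cl)cc2o1` reaches only the limit of this assay, > 25000 nM, so no number is known for it. Compound 3 `CCOC(=O)c1cc(=O)c2cc(CSC(=S)N(C(C)C)C(C)C)ccc2o1` also stops at a limit in this assay, at > 25000 nM. For the measured compounds named here, compound 2 thus stands at the limit of > 25000 nM in this assay, at which 2 of the 3 values shown sit, and the single measured number, that of compound 1, lies well inside the range. Going by the values given here, no two measured compounds differ in one place, so no measured step is available to lean on.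

Compound 4 `O=c1cc(CSC(=S)N2CCCC2)oc2cc(Cl)ccc12` is not yet measured. It differs from compound 2 in one place: pyrrolidin-1-yl in place of diethylamino on a thiocarbonyl carbon. The change keeps the number of heavy atoms and adds the ring. Compound 2 stands at a limit, so a large shift is not expected. The step expected here is a number no higher from compound 2 to compound 4 (the limit leaves the size open), most likely within the scatter. Compound 4 is estimated at 25000 nM in this assay, with a range from 9000 nM to 70000 nM, and a fair chance that the assay again returns only a limit.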

Compound 4, half-maximal inhibitory concentration: > 25000 nM
Compound 4: no number, only a limit; the forecaster's own chance of this, stated with the estimate: 55%; the middle value lies on the limit itself.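

Compound 2 and compound 4 both stop at a limit in this assay, so no step can be read for pyrrolidin-1-yl in place of diethylamino: the limit of > 25000 nM in this assay, at which 3 of the 4 values shown sit.

The compounds shown leave open whether these two groups differ at all in this read-out on the core of compound 2.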